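A few compounds are considered here, and "the series" means these few. Any claim that something is new, unique, unknown or untested is made for them only; others in the source may bear on it.

In a functional assay on PC-3 cells (Homo sapiens) for inhibition, read by sulforhodamine B assay, with a stated time of 72 h (on this read-out lower numbers stand for stronger inhibition and higher numbers for weaker inhibition), compound 1 (`Nc1sc(-c2ccc(Cl)cc2)c(-c2ccc(Cl)cc2)c1C(=O)NC1CCC1`) gives 24800 nM and compound 2 (`CN1CCN(C(=O)c2c(N)sc(-c3ccc(Cl)cc3)c2-c2ccc(Cl)cc2)CC1`) gives 13100 nM on the same core. Compound 2 therefore has no separate standing, since the two numbers lie within the scatter of each other. Compound 3 (`Nc1sc(-c2ccc(Cl)cc2)c(-c2ccc(Cl)cc2)c1C(=O)NCc1ccccc1`) differs from compound 2 on a carbonyl carbon, with benzylamino in place of 4-methylpiperazin-1-yl, and benzylamino in place of 4-methylpiperazin-1-yl on a carbonyl carbon gives the full count of that change. Among the compounds with values here, the one measured step that bears on it is the exchange at the same kind of carbonyl carbon, where a 1.9-fold lower number from compound 1 to compound 2 (0.28 log units; within the scatter) stayed within the scatter when 4-methylpiperazin-1-yl took the place of cyclobutylamino. Within the data shown here, no measured compound carries benzylamino, so this single step is thin support and the range has to stay wide. On that basis, no step beyond the scatter is expected in this assay for the new group. The expected move is a 1.2-fold higher number from compound 2 to compound 3 (0.09 log units; within the scatter) at the estimate, slightly upward if it shows at all. For compound 3 the estimated value is 16000 nM with an expected range from 6500 nM to 40000 nM in this read-out.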

Compound 3, half-maximal inhibitory concentration: 31800 nM
Compound 3: the middle estimate sits 2.0-fold (0.30 log units) below what was measured; the measured number falls inside the stated range.
By their numbers in this assay, from the lowest: compounds 2, 1 and 3 (each within the scatter of the next, the first and the last beyond it).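

In this assay the exchange on the carbonyl carbon now yields a step that stands clear of the scatter: benzylamino in place of 4-methylpiperazin-1-yl gives a 2.4-fold higher number from compound 2 to compound 3 (0.39 log units; beyond the scatter), a modest step, whereas the earlier exchange of cyclobutylamino for 4-methylpiperazin-1-yl stayed within it. Within the data shown here, on the amide-type nitrogen, benzyl in place of cyclobutyl gives a 1.3-fold higher number from compound 1 to compound 3 (0.11 log units; within the scatter), so these two groups cannot be told apart in this read-out, and only the pair of compound 2 and compound 3 is separated. Nothing available here says why 4-methylpiperazin-1-yl and benzylamino differ.

The compounds shown leave open how other groups on the same carbonyl carbon would read, for example morpholin-4-yl, piperazin-1-yl without the methyl, or a longer chain such as phenethylamino. They also leave open whether a change elsewhere on the shared core, such as methoxy in place of the chloro groups, would move the numbers further than any exchange on the carbonyl carbon has so far.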